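The source may report more compounds than this note shows. Statements on the series, on what has been measured and on what is new or still open speak of the compounds shown alone.

Values in a functional assay on HepG2 cells (Homo sapiens) for antiproliferative activity, read by MTT assay, with a stated time of 72 h (a higher number here means a weaker inhibitor, a lower number a stronger inhibitor), so far:
compound 1 `COc1ccc(OCCCON2C(N)=NC(N)=NC23CCOCC3)cc1`: "not determined" (no result reported)
compound 2 `NC1=NC2(CCOCC2)N(OCCCOc2cccc(Cl)c2Cl)C(N)=N1`: 330 nM
compound 3 `NC1=NC2(CCOCC2)N(OCCCOc2ccc(F)cc2)C(N)=N1`: "not determined" (no result reported)

Going by the values given here, compound 1 stands without a number in this assay, and compound 3 likewise; compound 2 is the only member of the set with a value. Compound 4 `NC1=NC2(CCOCC2)N(OCCCOc2ccccc2Br)C(N)=N1` differs from compound 1 by 2-bromophenyl in place of 4-methoxyphenyl on an oxygen on a saturated carbon. Among the compounds with values here, no step between measured compounds is available, so the step from compound 1 to compound 4 in this assay has no measured reference; a shift of this kind is expected to stay within, or only slightly beyond, the usual scatter, in no firm direction. Compound 4 is expected to give about 500 nM in this assay, with a range of 150 nM to 2500 nM. Within the data shown here, this expectation rests on compound 2 alone, whose value 330 nM is the only number in the set.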

Compound 4, half-maximal inhibitory concentration: 860 nM
Compound 4: middle estimate off by 1.7-fold (0.24 log units), on the low side; the range from low to high includes it.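

In this assay, the group on the oxygen on a saturated carbon now has its first measured step: 2-bromophenyl in place of 2,3-dichlorophenyl gives a 2.6-fold higher number from compound 2 to compound 4 (0.42 log units; beyond the scatter), a modest change beyond the scatter. The series therefore responds to a change in this aryl group, at least across this pair. Nothing measured bears on the reason for this step. Steps involving compound 1 and compound 3 cannot be read. Still open, from the compounds shown here alone, is how an amine or a carboxylic acid on this aromatic ring, or a longer chain leading to it, would behave in this assay.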